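The source may report more compounds than this note shows. Statements on the series, on what has been measured and on what is new or still open speak of the compounds shown alone.

In an ADME assay on cells (Macrophage) for cytotoxicity, read by MTT assay, with a stated time of 24 h (on this read-out higher numbers stand for lower toxicity in this test and lower numbers for higher toxicity in this test), compound 1 `O=C(/C=C/c1cccc([N+](=O)[O-])c1)NNC(=O)c1ccc2c(c1)OCCO2` gives 323000 nM and compound 2 `Cc1cccc(/C=C/C(=O)NNC(=O)c2ccc3c(c2)OCCO3)c1` gives 281000 nM, so compound 2 stands level with compound 1 within the usual scatter. Compound 3 `COc1ccc(/C=C/C(=O)NNC(=O)c2ccc3c(c2)OCCO3)cc1` carries 4-methoxyphenyl in place of 3-methylphenyl on a double-bonded chain carbon bound to a double-bonded chain carbon. Within the data shown here, the only measured step, a 1.1-fold lower number from compound 1 to compound 2 (0.06 log units; within the scatter), swaps a different pair of groups and stays within the scatter, so no step beyond the scatter is expected in this assay. The expected change is a 1.1-fold higher number from compound 2 to compound 3 (0.03 log units; within the scatter). The estimate for compound 3 is 300000 nM, with a range of 170000 nM to 520000 nM.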

Compound 3, half-maximal cytotoxic concentration: 319000 nM
Compound 3: middle estimate off by 1.1-fold (0.03 log units), on the low side; the range from low to high includes it.
By their numbers in this assay, from the lowest: compounds 2, 3 and 1 (each within the scatter of the next).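

In this assay the steps of a 1.1-fold higher number from compound 2 to compound 3 (0.06 log units; within the scatter) and a 1.0-fold lower number from compound 1 to compound 3 (0.01 log units; within the scatter) both bring in 4-methoxyphenyl on a double-bonded chain carbon bound to a double-bonded chain carbon. A third aromatic group, this one holding an oxygen, therefore leaves the number level with the other two, so 3-nitrophenyl, 3-methylphenyl and 4-methoxyphenyl cannot be told apart at this place. Nothing available explains this result. Still open, from the compounds shown here alone, is whether the number stays level with a different kind of group here, such as a phenyl ring carrying an amine or a carboxylic acid, or a longer chain in place of the ring.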